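A few compounds are considered here, and "the series" means these few. Any claim that something is new, unique, unknown or untested is made for them only; others in the source may bear on it.

In a functional assay on HGC-27 cells (Homo sapiens) for cytotoxicity, read by MTT assay, with a stated time of 48 h (a higher number here means a weaker inhibitor, a lower number a stronger inhibitor), two compounds have been measured so far. Compound 1 `COc1ccc(/C=C/C(=O)/C=C/c2cc3ccccc3nc2Oc2ccc(Br)cc2)cc1OC` gives > 10000 nM, which is a limit of the assay and not a number. Compound 2 `COc1ccc(OC)c(/C=C/C(=O)/C=C/c2cc3ccccc3nc2Oc2cccc(Cl)c2)c1` gives > 10000 nM, which is also a limit. Compound 2 therefore has no number of its own, only (the limit of > 10000 nM in this assay, at which 2 of the 2 values shown sit).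

Compound 3 `COc1ccc(/C=C/C(=O)/C=C/c2cc3ccccc3nc2Oc2cccc(Cl)c2)cc1OC` has the same atoms as compound 2, joined differently: 3,4-dimethoxyphenyl in place of 2,5-dimethoxyphenyl on a double-bonded chain carbon bound to a double-bonded chain carbon. In words, 3,4-dimethoxyphenyl stands in place of 2,5-dimethoxyphenyl on a double-bonded chain carbon bound to a double-bonded chain carbon. Compound 1 also carries 3,4-dimethoxyphenyl, and its result is the limit > 10000 nM. On that basis, no change beyond the usual scatter is expected in either direction, and the estimated step is a number no higher from compound 2 to compound 3 (the limit leaves the size open). For compound 3, the expected value in this assay is 10000 nM, with an estimated range from 3000 nM to 30000 nM.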

Compound 3, half-maximal inhibitory concentration: > 10000 nM
Compound 3: no number, only a limit (the forecaster's own chance of this, stated with the estimate: 65%); the middle value lies on the limit itself.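

No step can be read from compound 2 or compound 1 to compound 3, because all three stop at the same assay limit, which is not a number: the limit of > 10000 nM in this assay, at which 3 of the 3 values shown sit. The compounds shown leave open whether either exchange, 3,4-dimethoxyphenyl for 2,5-dimethoxyphenyl or 3-chlorophenyl for 4-bromophenyl, changes activity in this assay.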